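This account rests on a few compounds, and the source may have more. Where it says the series, first, only, none or still open, it means among the compounds named here.

Compound 3 `CCc1ccc(-n2cc(COc3cccc(NC(=O)Nc4ccc(Cl)c(C(F)(F)F)c4)c3)nn2)cc1` stands second highest of the three numbers in a functional assay on HepG2 cells (Homo sapiens) for inhibition, read by MTT assay, with a stated time of 72 h (on this read-out lower numbers stand for stronger inhibition and higher numbers for weaker inhibition), giving 1950 nM. Its nearest neighbour is compound 1 `O=C(Nc1cccc(OCc2cn(-c3ccccc3)nn2)c1)Nc1ccc(Cl)c(C(F)(F)F)c1`, which gives 1780 nM; compound 2 `CCc1ccccc1-n1cc(COc2cccc(NC(=O)Nc3ccc(Cl)c(C(F)(F)F)c3)c2)nn1` gives 3530 nM. Among the measured compounds shown here, the steps so far are a 1.1-fold higher number from compound 1 to compound 3 (0.04 log units; within the scatter), a 2.0-fold higher number from compound 1 to compound 2 (0.30 log units; within the scatter) and a 1.8-fold lower number from compound 2 to compound 3 (0.26 log units; within the scatter), none beyond the scatter.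

Compound 4 `O=C(Nc1cccc(OCc2cn(-c3ccccc3Br)nn2)c1)Nc1ccc(Cl)c(C(F)(F)F)c1` differs from compound 3 as follows: 2-bromophenyl in place of 4-ethylphenyl on an aromatic nitrogen. The step bearing most on this is a 1.8-fold lower number from compound 2 to compound 3 (0.26 log units; within the scatter), since it also swaps the substituent between two positions of the phenyl on the aromatic nitrogen; the unsubstituted phenyl of compound 1 sits within the scatter of both. No step beyond the scatter is therefore expected for compound 4, at most a drift toward the number of compound 2. Compound 4 is estimated at 2500 nM, range 1200 nM to 5500 nM, meaning an expected step of a 1.3-fold higher number from compound 3 to compound 4 (0.11 log units; within the scatter).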

Compound 4, half-maximal inhibitory concentration: 2810 nM
For compound 4 the middle estimate is 1.1-fold (0.05 log units) below the measured one, and the stated range covers the measured number.
By their numbers in this assay, from the lowest: compounds 1, 3, 4 and 2 (each within the scatter of the next).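

With 2-bromophenyl on the aromatic nitrogen, this assay still shows no step beyond the scatter, whether bromo replaces 4-ethylphenyl as a whole (a 1.4-fold higher number from compound 3 to compound 4 (0.16 log units; within the scatter)), ethyl on the same phenyl (a 1.3-fold lower number from compound 2 to compound 4 (0.10 log units; within the scatter)) or hydrogen (a 1.6-fold higher number from compound 1 to compound 4 (0.20 log units; within the scatter)). A halogen on this phenyl therefore behaves like ethyl or hydrogen in this series, so the flat picture at this position now extends beyond alkyl substitution. No measurement shown here explains this flat picture.

As far as these compounds go, it remains open whether an amine, a carboxylic acid or a chain longer than ethyl on this phenyl would produce a step beyond the scatter.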